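Swapping a Nitroethyl Arm for a Difluorophenyl Ring

A few compounds are considered here, and "the series" means these few. Any claim that something is new, unique, unknown or untested is made for them only; others in the source may bear on it.

Of the compounds shown here, two sharing one core have been measured. Compound 1 `COC(=O)C1=C(C)NC(C)=C(C(=O)OCCCl)C1c1cccc([N+](=O)[O-])c1` gives 22 nM in a functional assay on HEK293 cells for antagonist activity at Voltage-dependent L-type calcium channel subunit alpha-1D (Rattus norvegicus), read by FLIPR; a higher number here means a weaker inhibitor, a lower number a stronger inhibitor. Compound 2 `COC(=O)C1=C(C)NC(C)=C(C(=O)OCC(C)[N+](=O)[O-])C1c1cccc([N+](=O)[O-])c1` gives 111 nM in this assay, the highest of the two numbers recorded, so it is the weaker inhibitor of the pair. Among the compounds with values here, the single measured step, a 5.0-fold higher number from compound 1 to compound 2 (0.70 log units; beyond the scatter), shows that changing the group on the saturated chain carbon bound to an oxygen next to a carbonyl group can shift the read-out beyond the scatter.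

Compound 3 `COC(=O)C1=C(C)NC(C)=C(C(=O)OCc2ccc(F)c(F)c2)C1c1cccc([N+](=O)[O-])c1` differs from compound 2 in that same place: 3,4-difluorophenyl in place of 1-nitroethyl on a saturated chain carbon bound to an oxygen next to a carbonyl group. Within the data shown here, no measured step covers an aromatic ring entering at this position, so the only guide is that the 1-nitroethyl group, which now leaves, went together with a weaker result in a 5.0-fold higher number from compound 1 to compound 2 (0.70 log units; beyond the scatter). On these data alone, its removal is expected to move the number back toward that of compound 1, although the contribution of the incoming ring is unknown. The step expected here is a 3.2-fold lower number from compound 2 to compound 3 (0.50 log units; beyond the scatter). Compound 3 is estimated at 35 nM, with a likely range from 9 nM to 140 nM.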

Compound 3, half-maximal inhibitory concentration: 20 nM
Compound 3: the middle estimate sits 1.8-fold (0.24 log units) above what was measured, within the range that was stated.
By their numbers in this assay, from the lowest: compounds 3 and 1 (each within the scatter of the next); then compound 2.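

Replacing 1-nitroethyl with 3,4-difluorophenyl on the saturated chain carbon bound to an oxygen next to a carbonyl group gives a 5.6-fold lower number from compound 2 to compound 3 (0.74 log units; beyond the scatter) in this assay, which shows that a six-membered aromatic ring of carbon only can stand at this position with no loss against the best number seen so far. Replacing chloromethyl with the same ring gives a 1.1-fold lower number from compound 1 to compound 3 (0.04 log units; within the scatter), so an open chain group and an aromatic ring cannot be told apart here, and among these three compounds only the 1-nitroethyl group of compound 2 stands apart, with the higher number and thus the weaker inhibition. Nothing at hand says why 1-nitroethyl differs from the other two groups.

On these data alone, whether the two fluorine atoms matter stays open, and a plain phenyl ring in this place would be the direct test. Also open, as far as these compounds go, is how a quite different group would behave here, such as an amine or a carboxylic acid, and whether a longer chain carrying the ring would change the number.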